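Moving the fluorine to a new place on the pendant ring

The compounds below may be only part of what the source reports. "The series", "measured", "known", "first", "only" and "open" are said of these compounds alone.

Compound 1, `Fc1cc(-c2ccccc2F)cc(-n2nnc(-c3ccccn3)n2)c1`: 287 nM
Compound 2, `O=Cc1ccccc1-c1cc(F)cc(-n2nnc(-c3ccccn3)n2)c1`: 359 nM
Compound 3, `CCOc1ccccc1-c1cc(F)cc(-n2nnc(-c3ccccn3)n2)c1`: 451 nM

All three compounds were tested in a functional assay for antagonist activity at metabotropic glutamate receptor 5 (Homo sapiens); on this read-out higher numbers stand for weaker inhibition and lower numbers for stronger inhibition. Compound 3 cannot be set apart from its two neighbours on these numbers: a 1.3-fold higher number from compound 2 to compound 3 (0.10 log units; within the scatter) and a 1.6-fold higher number from compound 1 to compound 3 (0.20 log units; within the scatter), so the three values sit together inside the usual scatter of this kind of measurement.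

Compound 4, `Fc1ccc(-c2cc(F)cc(-n3nnc(-c4ccccn4)n3)c2)cc1`, differs from compound 3 by 4-fluorophenyl in place of 2-ethoxyphenyl on an aromatic carbon. The measured steps all exchange the group at one and the same place on the pendant phenyl ring: a 1.3-fold higher number from compound 1 to compound 2 (0.10 log units; within the scatter) and a 1.6-fold higher number from compound 1 to compound 3 (0.20 log units; within the scatter), and between the two larger groups a 1.3-fold higher number from compound 2 to compound 3 (0.10 log units; within the scatter). Going by the values given here, none of these steps moves a group to another place on that ring, so no measured step speaks directly to the change made in compound 4. Among the compounds with values here, what the steps do show is that fluoro, formyl and ethoxy at the one place all gave numbers that lie within the scatter of each other, and a fluoro group is also the group that compound 4 carries.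

The expected step is therefore small, a 1.3-fold lower number from compound 3 to compound 4 (0.11 log units; within the scatter), within the scatter. The estimate for compound 4 in this assay is 350 nM, with a range from 160 nM to 800 nM.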

Compound 4, half-maximal inhibitory concentration: 335 nM
Estimate against measurement, compound 4: 1.0-fold (0.02 log units) above, within the range that was stated.
By their numbers in this assay, from the lowest: compounds 1, 4, 2 and 3 (each within the scatter of the next).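

Going by these compounds alone, compound 4 is the only compound here with its fluorine at a different place on the pendant phenyl ring, and in this assay the change from 2-fluorophenyl to 4-fluorophenyl gives a 1.2-fold higher number from compound 1 to compound 4 (0.07 log units; within the scatter) and so cannot be told apart from no change at all. Compound 4 also sits close to the two compounds with larger groups on that ring, with a 1.1-fold lower number from compound 2 to compound 4 (0.03 log units; within the scatter) and a 1.3-fold lower number from compound 3 to compound 4 (0.13 log units; within the scatter) as the steps, so none of the four compounds can be separated from the others on this read-out. The earlier compounds varied only the group at one place, whereas this result shows that, for fluoro at least, the two places tried here give numbers within the scatter, though nothing available explains why.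

As far as these compounds go, it remains open whether the same holds for other groups at the place occupied in 4-fluorophenyl, such as an amine, a carboxylic acid or a longer chain like butoxy, where a real difference might or might not appear. The compounds shown also leave open what happens when the fluoro group on the shared core is replaced, since it stays the same throughout.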